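Moving One Fluorine on a Weakly Cytotoxic Compound

The source may report more compounds than this note shows. Statements on the series, on what has been measured and on what is new or still open speak of the compounds shown alone.

Compound 1 `Fc1cc(F)cc(/C=N/NC(=S)Nc2cccc3ccccc23)c1` was tested in a functional assay on A549 cells (Homo sapiens) for cytotoxicity, read by XTT assay, with a stated time of 24 h; on this read-out lower numbers stand for stronger inhibition and higher numbers for weaker inhibition. In this assay compound 1 gives 500 ug/mL, the highest of the two plain numbers in hand, which here means the weakest inhibition of the measured pair. Compound 2 `Fc1ccc(Oc2ccc(/C=N/NC(=S)Nc3cccc4ccccc34)cc2)cc1` carries a different group on the same carbon; in this assay compound 2 gives 62.5 ug/mL, and the gap between compound 2 and compound 1 goes beyond the usual scatter. Compound 3 `Fc1cc(F)c(/C=N/NC(=S)Nc2cccc3ccccc23)c(F)c1` reaches only a limit of the assay: in this assay compound 3 gives > 500 ug/mL, which is a limit rather than a number, and the limit of > 500 ug/mL in this assay, at which 1 of the 3 values shown sits, marks where that result sits. Within the data shown here, no step between two compounds that differ in a single place has been measured, so nothing here shows how one small change shifts the read-out.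

Compound 4 `Fc1ccc(F)c(/C=N/NC(=S)Nc2cccc3ccccc23)c1` is the compound still to be measured. 2,5-difluorophenyl in place of 3,5-difluorophenyl on a carbon with a double bond to nitrogen The two have the same atoms, joined differently. Both measured compounds bearing two fluorines sit at the weak end, so for compound 4 a step of no change at the digits printed from compound 1 to compound 4 (within the scatter) is expected, nothing beyond the scatter, because compound 1 gives 500 ug/mL. The estimated value for compound 4 is 500 ug/mL, within a range from 125 ug/mL to 1000 ug/mL.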

Compound 4, half-maximal inhibitory concentration: 500 ug/mL
Beside the measured number, compound 4's estimate shows no gap at the digits printed; low and high end bracket the measured number.
By their numbers in this assay, from the lowest: compound 2; then compounds 1 and 4 (each within the scatter of the next).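

In this assay, among these compounds, the one change that can be read so far, 2,5-difluorophenyl in place of 3,5-difluorophenyl, gives no change at the digits printed from compound 1 to compound 4 (within the scatter). Among the compounds shown here, this is the first pair that differs in one place, and it shows that on a carbon with a double bond to nitrogen these two arrangements of the same atoms cannot be told apart by this read-out, even though moving a fluorine changes the structure without changing the atom count. The comparison sits at the weak end of the numbers in hand, and compound 3 gives only a limit of the assay, not a number: the limit of > 500 ug/mL in this assay, at which 1 of the 4 values shown sits.

A single step with no visible change says little about the rest of the series, and it cannot show whether any other placement of the two fluorines would also leave the read-out where it is. Going by these compounds, whether a different group on the phenyl ring, such as a methoxy group, an amine or a carboxylic acid, would move the number beyond the scatter remains open.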